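Swapping isopropyl for methyl on a ring amine nitrogen

A few compounds are considered here, and "the series" means these few. Any claim that something is new, unique, unknown or untested is made for them only; others in the source may bear on it.

Two compounds have values so far in a functional assay on HCT-116 cells (Homo sapiens) for cytotoxicity, read by MTT assay, with a stated time of 3 days (a higher number here means a weaker inhibitor, a lower number a stronger inhibitor), and they are these:
- compound 1 `CC(C)(C)c1cc2c(N/N=C/c3ccc4c(c3)CNCC4)ncnc2s1` gives 0.107 ug/mL
- compound 2 `CC(C)N1Cc2ccc(/C=N/Nc3ncnc4sc(C(C)(C)C)cc34)cc2C1` gives 0.206 ug/mL

Compound 2 stands within the usual scatter of compound 1, so these two values do not separate. Compound 3 `CN1Cc2ccc(/C=N/Nc3ncnc4sc(C(C)(C)C)cc34)cc2C1` carries methyl in place of isopropyl on an amine nitrogen in a ring. Going by the values given here, no measured pair isolates this change, so no step beyond the scatter is expected in this assay in either direction. The estimate is a 1.4-fold lower number from compound 2 to compound 3 (0.14 log units; within the scatter) and this stays within the scatter. Compound 3 is expected at 0.15 ug/mL with an estimated range from 0.06 ug/mL to 0.4 ug/mL in this assay.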

Compound 3, half-maximal inhibitory concentration: 0.088 ug/mL
Compound 3: the middle estimate sits 1.7-fold (0.23 log units) above what was measured; measured number inside the range.
By their numbers in this assay, from the lowest: compounds 3, 1 and 2 (each within the scatter of the next, the first and the last beyond it).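

In this assay, going by these compounds alone, the group on this amine nitrogen in a ring does register: methyl in place of isopropyl gives a 2.3-fold lower number from compound 2 to compound 3 (0.37 log units; beyond the scatter) and so provides the first step beyond the scatter at this position. The step is modest and rests on this single pair. Nothing measured here explains it.

On these data alone, whether ethyl or cyclopropyl on the same nitrogen would give a number nearer compound 2 or compound 3 remains open. Two groups at one position define no trend, and an acetyl group could behave differently from either.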